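A Bromine Added to the Benzyl Group

The compounds below may be only part of what the source reports. "The series", "measured", "known", "first", "only" and "open" are said of these compounds alone.

Compound 2 `O=C(/C=C/c1ccc(OCc2cn(Cc3ccccc3)nn2)cc1)c1ccc(Br)cc1` stands lowest of the two measured compounds. In a functional assay on MCF7 cells (Homo sapiens) for inhibition, read by MTT assay, with a stated time of 48 h, tested at 10 uM (on this read-out higher numbers stand for more inhibition of growth at the one concentration tested and lower numbers for less inhibition of growth), compound 2 gives 34%, while compound 1 `C#CCOc1ccc(/C=C/C(=O)c2ccc(Br)cc2)cc1` gives 45%, a gap beyond the usual scatter. Compound 3 `O=C(/C=C/c1ccc(OCc2cn(Cc3ccccc3Br)nn2)cc1)c1ccc(Br)cc1` differs from compound 2 by bromo in place of hydrogen on an aromatic carbon. Going by the values given here, no measured pair shows this change, so its effect in this assay is unknown; a step of this kind is expected to be small, with no clear direction beyond the scatter. Compound 3 is therefore estimated at 38%, with a range from 20% to 56%. That estimate corresponds to an expected step of a number 4 percentage points higher from compound 2 to compound 3 (within the scatter).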

Compound 3, percent growth inhibition at one concentration: 44%
Compound 3: the middle estimate sits 6 percentage points below what was measured, and the stated range covers the measured number.
By their numbers in this assay, from the lowest: compounds 2, 3 and 1 (each within the scatter of the next, the first and the last beyond it).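

Going by these compounds alone, the first measured pair at this position is 2-bromobenzyl against benzyl: in this assay, bromo in place of hydrogen on an aromatic carbon, ortho to a large group, gives a number 10 percentage points higher from compound 2 to compound 3 (within the scatter). Within the data shown here, the position therefore takes a bromo without a difference that can be told from the scatter, which the earlier compounds could not show. Nothing at hand bears on the reason for this result. The compounds shown leave open how an amine or a carboxylic acid would read on this ring, and whether bromo elsewhere on it would read the same.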